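The source may report more compounds than this note shows. Statements on the series, on what has been measured and on what is new or still open speak of the compounds shown alone.

In a functional assay on OVCAR-3 cells (Homo sapiens) for inhibition, read by MTT assay, with a stated time of 24 h (a lower number here means a stronger inhibitor, a higher number a weaker inhibitor), compound 1 `CC1(C)[C@H]2CC[C@]1(C)N(Cc1cn(-c3ccc(C#N)cc3)nn1)C(=O)C2` gives 380 nM while compound 2 `CC1(C)[C@H]2CC[C@]1(C)N(Cc1cn(-c3ccc(F)cc3)nn1)C(=O)C2` gives 200 nM and compound 3 `CC1(C)[C@H]2CC[C@]1(C)N(Cc1cn(-c3cccc(Cl)c3)nn1)C(=O)C2` gives 50 nM as the lowest of the three numbers. Going by the values given here, compound 4 `Cc1ccc(-n2cc(CN3C(=O)C[C@@H]4CC[C@@]3(C)C4(C)C)nn2)cc1` has not yet been measured and carries 4-methylphenyl in place of 3-chlorophenyl on an aromatic nitrogen as its one change from compound 3. Among the compounds with values here, two steps bear on this: a 4.0-fold lower number from compound 2 to compound 3 (0.60 log units; beyond the scatter) and a 7.6-fold lower number from compound 1 to compound 3 (0.88 log units; beyond the scatter) are both modest and beyond the scatter and each brought in 3-chlorophenyl, whereas a 1.9-fold lower number from compound 1 to compound 2 (0.28 log units; within the scatter) stays within the scatter. With compound 2 at 200 nM as the closest guide, a modest step upward is expected in this assay on leaving 3-chlorophenyl. The expected step is a 3.0-fold higher number from compound 3 to compound 4 (0.48 log units; beyond the scatter) in this estimate. Compound 4 is estimated at 150 nM with a range from 50 nM to 400 nM expected.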

Compound 4, half-maximal inhibitory concentration: 40 nM
For compound 4 the middle estimate is 3.8-fold (0.57 log units) above the measured one; the whole stated range lies above it.
By their numbers in this assay, from the lowest: compounds 4 and 3 (each within the scatter of the next); then compounds 2 and 1 (each within the scatter of the next).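

In this assay, 4-methylphenyl and 3-chlorophenyl on the aromatic nitrogen cannot be told apart (a 1.3-fold lower number from compound 3 to compound 4 (0.10 log units; within the scatter)), so the low numbers at this position do not depend on a chlorine-bearing ring. On the ring carbon that holds fluoro in compound 2 and cyano in compound 1, methyl brings clear gains (first a 5.0-fold lower number from compound 2 to compound 4 (0.70 log units; beyond the scatter), then a 9.5-fold lower number from compound 1 to compound 4 (0.98 log units; beyond the scatter)), showing that this carbon responds to what it carries. Nothing available here accounts for these steps. The compounds shown leave open how an amine or a carboxylic acid on the phenyl ring would read, and whether a longer chain such as ethyl in place of methyl would hold these numbers.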